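Swapping thiophen-2-yl for 5-chloro-2-hydroxyphenyl in compound 3

The source may hold more compounds than are shown below. What is called first, only, known or untested is meant among the compounds shown, and "the series" means these compounds.

Compound 2 (`COc1ccc(C(=O)/C=C/c2cccs2)c2c1C=CC(C)(C)O2`) was tested in a functional assay on HepG2 cells (Homo sapiens) for antiproliferative activity, read by MTT assay, with a stated time of 24 h; a lower number here means a stronger inhibitor, a higher number a weaker inhibitor. In this assay compound 2 gives > 10000 nM, which is a limit of the assay and not a number. Its neighbour compound 1 (`COc1ccc(C(=O)/C=C/c2cccc(F)c2)c2c1C=CC(C)(C)O2`) was tested the same way. In this assay compound 1 gives > 10000 nM, again a limit. The step that the two limits leave unreadable from compound 1 to compound 2 therefore cannot be read, and both values sit at the same ceiling, as the limit of > 10000 nM in this assay, at which 2 of the 2 values shown sit, records. Compound 3 (`COc1ccc(C(=O)/C=C/c2cc(Cl)ccc2O)c2c1C=CC(C)(C)O2`) differs from compound 2 in one place: 5-chloro-2-hydroxyphenyl in place of thiophen-2-yl on a double-bonded chain carbon bound to a double-bonded chain carbon. Going by the values given here, no measured step bears on this change, since the only measured step, a step that the two limits leave unreadable from compound 1 to compound 2, has no readable size. With the starting point itself at a limit, the expectation is simply that the step that the limit leaves unreadable from compound 2 to compound 3 does not reach beyond the usual scatter. Compound 3 is therefore estimated at 15000 nM, with a range from 3000 nM to 60000 nM, and a fair chance that only a limit is reported again.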

Compound 3, half-maximal inhibitory concentration: 6640 nM
For compound 3 the middle estimate is 2.3-fold (0.35 log units) above the measured one; measured number inside the range.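

In this assay, compound 3 is the only compound shown that gives a number and not a limit, so this place on the chain now has one readable value. The change to 5-chloro-2-hydroxyphenyl can be read only as a floor, an at least 1.5-fold lower number from compound 2 to compound 3 (0.17 log units; that floor lies within the scatter), and the change from the fluorinated ring gives the same kind of floor, an at least 1.5-fold lower number from compound 1 to compound 3 (0.17 log units; that floor lies within the scatter), so neither step is shown to go beyond the scatter, although the true steps could be larger. The ceiling of the assay still sets how much can be read here: the limit of > 10000 nM in this assay, at which 2 of the 3 values shown sit.

The group enters as a whole, so the compounds shown do not separate the part played by the chlorine from that of the hydroxyl. Going by these compounds, how an amine or a carboxylic acid in this same place would read also stays open.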